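A few compounds are considered here, and "the series" means these few. Any claim that something is new, unique, unknown or untested is made for them only; others in the source may bear on it.

Measured compounds:
- compound 1 `Oc1ccc(-c2nc3ccccc3s2)cc1O`: 220 nM
- compound 2 `Oc1ccc(-c2nc3cc(F)ccc3s2)cc1O`: 190 nM
- compound 3 `COc1ccc(-c2nc3cc(F)ccc3s2)cc1O`: 50 nM

In a functional assay on MDA-MB-468 cells (Homo sapiens) for antiproliferative activity (on this read-out higher numbers stand for weaker inhibition of growth and lower numbers for stronger inhibition of growth), compound 2 sits with the second highest number of the three; compound 1 is within the scatter of it, while compound 3 lies beyond the scatter a 3.8-fold lower number from compound 2 to compound 3 (0.58 log units; beyond the scatter). The step from compound 2 to compound 4 `COc1cc(-c2nc3cc(F)ccc3s2)ccc1O` is methyl in place of hydrogen on an oxygen on an aromatic ring, a change applied at a different oxygen of the shared core than in compound 3. For the measured compounds named here, the only comparable step is a 3.8-fold lower number from compound 2 to compound 3 (0.58 log units; beyond the scatter), a modest gain. A gain of similar kind is therefore expected for compound 4, though its size is uncertain, since the change sits elsewhere. For compound 4 the expected value in this assay is 100 nM, between 40 nM and 300 nM, an expected step of a 1.9-fold lower number from compound 2 to compound 4 (0.28 log units; within the scatter).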

Compound 4, concentration for 50% growth inhibition: 170 nM
Compound 4: the middle estimate sits 1.7-fold (0.23 log units) below what was measured, within the range that was stated.
By their numbers in this assay, from the lowest: compound 3; then compounds 4, 2 and 1 (each within the scatter of the next).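

In this assay the change from hydroxy to methoxy at this oxygen gives a 1.1-fold lower number from compound 2 to compound 4 (0.05 log units; within the scatter) and so leaves no difference that can be told from the scatter. The same change at the other oxygen of the shared core gives a 3.8-fold lower number from compound 2 to compound 3 (0.58 log units; beyond the scatter) and lies beyond the scatter, so among these compounds the outcome depends on which oxygen carries the methyl. Nothing available explains why the two oxygens differ. Still open, on these data alone, is whether a longer chain such as ethyl on this oxygen, or an amine in place of the hydroxy, would shift the number.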